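This account rests on a few compounds, and the source may have more. Where it says the series, first, only, none or still open, it means among the compounds named here.

In a functional assay on PC-3 cells (Homo sapiens) for cytotoxicity, read by sulforhodamine B assay, with a stated time of 72 h (a higher number here means a weaker inhibitor of growth, a lower number a stronger inhibitor of growth), compound 3 `CCCCCCCCC(=O)N1c2ccccc2CCC1C(=O)Nc1cc(C(F)(F)F)cc(C(F)(F)F)c1` gives 7430 nM, the highest of the two numbers recorded. Its nearest neighbour is compound 2 `O=C(Nc1cc(C(F)(F)F)cc(C(F)(F)F)c1)C1CCc2ccccc2N1C(=O)c1ccc(Cl)cc1`, which gives 4230 nM; the gap a 1.8-fold higher number from compound 2 to compound 3 (0.24 log units; within the scatter) is within the usual scatter. Compound 1 `CC(=O)N1c2ccccc2CCC1C(=O)Nc1cc(C(F)(F)F)cc(C(F)(F)F)c1` gives only a limit, > 70000 nM, a value at the edge of what this assay can report, as noted in the limit of > 70000 nM in this assay, at which 1 of the 3 values shown sits.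

Compound 4 `O=C(Nc1cc(C(F)(F)F)cc(C(F)(F)F)c1)C1CCc2ccccc2N1` differs from compound 3 by hydrogen in place of octylcarbonyl on a nitrogen on an aromatic ring in a ring. The measured steps that bear on this are an at least 9.4-fold lower number from compound 1 to compound 3 (0.97 log units; beyond the scatter) and an at least 16-fold lower number from compound 1 to compound 2 (1.21 log units; beyond the scatter): both times, building out the group on the ring nitrogen beyond a bare methyl took the number from the limit down to a measurable value. Compound 4 goes the other way, removing the whole acyl group, so the number is expected to rise, plausibly back toward a limit. The step is estimated at an 8.1-fold higher number from compound 3 to compound 4 (0.91 log units; beyond the scatter). Compound 4 is therefore estimated at 60000 nM, with a range from 12000 nM to 300000 nM.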

Compound 4, concentration for 50% growth inhibition: 8120 nM
Compound 4: middle estimate off by 7.4-fold (0.87 log units), on the high side, outside the stated range (below it).
By their numbers in this assay, from the lowest: compounds 2, 3 and 4 (each within the scatter of the next). At a limit, above all of these: compound 1.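

Hydrogen on this ring nitrogen gives a number that sits with those of the two larger acyl groups, not with that of the acetyl group: in this assay, a 1.1-fold higher number from compound 3 to compound 4 (0.04 log units; within the scatter), and a 1.9-fold higher number from compound 2 to compound 4 (0.28 log units; within the scatter). An acyl group is therefore not needed here for a measurable number, and these compounds show no simple trend with group size, since only the acetyl compound stands apart: an at least 8.6-fold lower number from compound 1 to compound 4 (0.93 log units; beyond the scatter). The value of compound 1 is a limit and not a number, so that step has only a lower bound: the limit of > 70000 nM in this assay, at which 1 of the 4 values shown sits.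

Going by these compounds, it remains open whether other short acyl groups, such as propionyl, behave like acetyl. On these data alone, it is also open whether a plain alkyl or benzyl group on this nitrogen, with no carbonyl, would behave like hydrogen.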